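Amide variation on the shared acrylamide core

The compounds below may be only part of what the source reports. "The series", "measured", "known", "first", "only" and "open" are said of these compounds alone.

Measured compounds:
compound 1, `CN1CCN(C(=O)/C=C/c2ccncc2-c2ccc3ccccc3c2)CC1`, > 10000 nM in a functional assay on KB cells (Homo sapiens) for inhibition, read by sulforhodamine B assay, with a stated time of 72 h; on this read-out higher numbers stand for weaker inhibition of growth and lower numbers for stronger inhibition of growth
compound 2, `CCOC(=O)/C=C/c1ccncc1-c1ccc2c(cnn2C)c1`, > 10000 nM in this assay
compound 3, `O=C(/C=C/c1ccncc1-c1ccc2cc[nH]c2c1)N1CCOCC1`, > 10000 nM in this assay

Every value above is a limit of this assay and not a number. Compound 1 reaches only a limit, > 10000 nM. Compound 2 likewise reaches only a limit, > 10000 nM. Compound 3 also reaches only a limit, > 10000 nM. Compound 1 therefore stands where the whole shown set stands, at the limit of > 10000 nM in this assay, at which 3 of the 3 values shown sit; no step between measured compounds can be drawn.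

Compound 4, `O=C(/C=C/c1ccncc1-c1ccc2ccccc2c1)NC1CC1`, differs from compound 1 by cyclopropylamino in place of 4-methylpiperazin-1-yl on a carbonyl carbon. Among the compounds with values here, with no measured step to lean on, the expected step that the limit leaves unreadable from compound 1 to compound 4 is none beyond the scatter. Compound 4 is expected in this assay to give about 12000 nM, within 3000 nM to 40000 nM, most probably again reported only as a limit.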

Compound 4, concentration for 50% growth inhibition: 6050 nM
Compound 4: middle estimate off by 2.0-fold (0.30 log units), on the high side, and the stated range covers the measured number.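

In this assay, within the data shown here, compound 4 gives 6050 nM, the first number that is not a limit, so a readable value is possible with cyclopropylamino on the carbonyl carbon. The change reads as an at least 1.6-fold lower number from compound 1 to compound 4 (0.21 log units; that floor lies within the scatter), so it cannot yet be called more than scatter. The set as a whole still sits mostly at the limit: the limit of > 10000 nM in this assay, at which 3 of the 4 values shown sit.

On these data alone, the true size of the step stays open, as the value of compound 1 is only a limit. Also open, as far as these compounds go, is whether a longer chain on the amide nitrogen, such as n-butylamino, gives a number in this assay.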